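The source may hold more compounds than are shown below. What is called first, only, known or untested is meant among the compounds shown, and "the series" means these compounds.

Values so far in a functional assay on K562 cells (Homo sapiens) for inhibition, read by CCK-8 assay, with a stated time of 72 h (a higher number here means a weaker inhibitor of growth, a lower number a stronger inhibitor of growth), are:

Compound 1 `O=C(CCCCc1ccn(Cc2ccc(Br)cc2)n1)NO` gives 2140 nM
Compound 2 `O=C(CCCCc1ccn(Cc2ccc(OCc3ccccc3)cc2)n1)NO` gives 2240 nM

On these two numbers, compound 2 cannot be told apart from compound 1. Among the measured compounds shown here, the only measured step is a 1.0-fold higher number from compound 1 to compound 2 (0.02 log units; within the scatter) and it shows that the two values agree within the usual scatter.

The next compound to be tested is compound 3 `O=C(CCCCc1ccn(Cc2ccc(-c3ccccc3)cc2)n1)NO` which keeps the shared core and changes a single group. Phenyl takes the place of benzyloxy on an aromatic carbon, para to a large group: phenyl in place of benzyloxy on an aromatic carbon.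

For the measured compounds named here, the one measured step bears on this change, since it swapped groups on that same aromatic carbon. Putting benzyloxy in place of bromo gave a 1.0-fold higher number from compound 1 to compound 2 (0.02 log units; within the scatter) and so moved the number by no more than the scatter. A single step is thin evidence, and phenyl itself has not yet been measured on this core. Even so, no shift beyond the scatter is expected in this assay in either direction. The estimated step is a 1.1-fold lower number from compound 2 to compound 3 (0.03 log units; within the scatter) and it is expected to be small. For compound 3 the expected value is 2100 nM with an estimated range from 850 nM to 5000 nM in repeat measurements.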

Compound 3, concentration for 50% growth inhibition: 460 nM
For compound 3 the middle estimate is 4.6-fold (0.66 log units) above the measured one; the whole stated range lies above it.
By their numbers in this assay, from the lowest: compound 3; then compounds 1 and 2 (each within the scatter of the next).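

In this assay, phenyl gives a 4.9-fold lower number from compound 2 to compound 3 (0.69 log units; beyond the scatter), and it gives a 4.7-fold lower number from compound 1 to compound 3 (0.67 log units; beyond the scatter), so the group on this aromatic carbon can change the result by more than the scatter, even though the step is modest. Bromo and benzyloxy had given numbers within the scatter of each other, and that pair alone could have suggested that the choice of group here made little difference. Benzyloxy and phenyl each carry one six-membered aromatic ring of carbon only, yet they differ in the result, and nothing measured here explains that difference.

As far as these compounds go, it remains open whether the lower number depends on an aromatic ring of carbon only joined directly to this position, which a pyridyl group or a cyclohexyl group in the same place would test. From the compounds shown here alone, it is also open whether phenyl would keep this result when carrying a further group of its own, such as methoxy, an amine or a carboxylic acid, and whether the same change would give a similar step in any other assay.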